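The compounds below may be only part of what the source reports. "The series", "measured", "known", "first", "only" and "open" are said of these compounds alone.

Compound 1 `N#C/C(=C\c1c(-c2ccccc2)[nH]c2ccccc12)C(N)=O` and compound 2 `Cc1ccc(S(=O)(=O)/C(C#N)=C/c2c(-c3ccccc3)[nH]c3ccccc23)cc1` share a core and differ only in the group attached to the double-bonded chain carbon that carries the nitrile. In a functional assay on MT4 cells (Homo sapiens) for antiproliferative activity, read by MTT assay, with a stated time of 96 h (a lower number here means that less compound is needed, a higher number that more compound is needed for the effect), compound 1 gives 6000 nM, the higher of the two numbers seen so far. Compound 2, which carries a methylphenyl sulfone in that position, gives 400 nM in this assay, and this gap lies beyond the scatter of repeated measurements.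

Compound 3 `N#C/C(=C\c1c(-c2ccccc2)[nH]c2ccccc12)C(=O)c1ccc(Cl)cc1` keeps the carbonyl of compound 1 but changes what sits on it: 4-chlorophenyl in place of amino on a carbonyl carbon. Within the data shown here, whether this step behaves like the one from compound 1 to compound 2 is unknown, since no direct comparison exists.

Given that a bulkier aryl-bearing group in compound 2 went with 400 nM, compound 3 is expected to come in with a lower number than compound 1, by a step of a 4.0-fold lower number from compound 1 to compound 3 (0.60 log units; beyond the scatter). The estimate for compound 3 in this assay is 1500 nM, with a likely range from 300 nM to 8000 nM.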

Compound 3, half-maximal effective concentration: 400 nM
The estimate for compound 3 lay 3.8-fold (0.57 log units) above the measured number; measured number inside the range.
By their numbers in this assay, from the lowest: compounds 2 and 3 (each within the scatter of the next); then compound 1.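

Keeping the carbonyl and changing only what sits on it makes a large difference at this position: replacing amino with 4-chlorophenyl gives a 15-fold lower number from compound 1 to compound 3 (1.18 log units; beyond the scatter) in this assay. The sulfone is also not the only link that goes with a low number here, since compound 3, with its carbonyl, gives 400 nM and compound 2, with its sulfone, gives 400 nM, two values within the scatter of each other. No measurement here explains why the change from amino to 4-chlorophenyl has this effect.

The compounds shown cannot separate the contribution of the aromatic ring from that of its chlorine. A plain phenyl on the carbonyl would address that question, while a methyl group there would show whether any carbon group in place of amino goes with a similar number.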